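The source may hold more compounds than are shown below. What is called first, only, known or untested is meant among the compounds shown, and "the series" means these compounds.

Measured so far in a functional assay on B16-F0 cells (Mus musculus) for inhibition, read by CCK-8 assay, with a stated time of 48 h; on this read-out higher numbers stand for weaker inhibition and lower numbers for stronger inhibition:

compound 1, `COc1cc(-c2ccnc3cc(-c4ccc(Cl)cc4)nn23)cc(OC)c1OC` — 4090 nM
compound 2, `COc1cc(-c2ccnc3cc(-c4cccc(C#N)c4)nn23)cc(OC)c1OC` — > 10000 nM, which is a limit of this assay rather than a number the limit of > 10000 nM in this assay, at which 1 of the 3 values shown sits.
compound 3, `COc1cc(-c2ccnc3cc(-c4ccc5cc[nH]c5c4)nn23)cc(OC)c1OC` — 55 nM

Compound 3 gives the lowest of the two real numbers, and its nearest neighbour is compound 1, with a 74-fold lower number from compound 1 to compound 3 (1.87 log units; beyond the scatter). The other steps in this series also swap the group on the same aromatic carbon of the shared core: an at least 2.4-fold higher number from compound 1 to compound 2 (0.38 log units; beyond the scatter) and an at least 180-fold lower number from compound 2 to compound 3 (2.25 log units; beyond the scatter). Every one of these changes the whole aryl group, so they show that this position tolerates large swings in both directions, but none of them alters only the indole ring.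

Compound 4, `COc1cc(-c2ccnc3cc(-c4ccc5cnn(C)c5c4)nn23)cc(OC)c1OC`, differs from compound 3 by 1-methyl-1H-indazol-6-yl in place of 1H-indol-6-yl on an aromatic carbon. Because a 74-fold lower number from compound 1 to compound 3 (1.87 log units; beyond the scatter) and an at least 180-fold lower number from compound 2 to compound 3 (2.25 log units; beyond the scatter) both point to this group driving the potency of compound 3, a smaller edit to that group is expected to cost something, but far less than the swaps already seen. The expected step is a 2.7-fold higher number from compound 3 to compound 4 (0.44 log units; beyond the scatter). Compound 4 is thus estimated at 150 nM, within a range from 40 nM to 800 nM.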

Compound 4, half-maximal inhibitory concentration: 1000 nM
Compound 4: middle estimate off by 6.7-fold (0.82 log units), on the low side; the measured number lies above the stated range.
By their numbers in this assay, from the lowest: compound 3; then compound 4; then compound 1. At a limit, above all of these: compound 2.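

The indole at this carbon does not keep its potency through what looks like a small edit: an 18-fold higher number from compound 3 to compound 4 (1.26 log units; beyond the scatter), so the exact fused group matters, not just having two fused rings here. The 1-methyl-1H-indazol-6-yl group still beats 4-chlorophenyl, with a 4.1-fold lower number from compound 1 to compound 4 (0.61 log units; beyond the scatter). Compound 2 stands at a limit of the assay and not at a real number, so its step can only be read as a bound: an at least 10-fold lower number from compound 2 to compound 4 (1.00 log units; beyond the scatter).

This one edit removes the hydrogen-bond donor, adds a ring nitrogen and adds a methyl together, and nothing given here separates these changes or explains the loss. Open, from the compounds shown here alone, is how 1H-indazol-6-yl and 1-methyl-1H-indol-6-yl, each carrying only part of the edit, would compare with compound 3.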